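Two nitrophenyl isomers on the shared core

The source may report more compounds than this note shows. Statements on the series, on what has been measured and on what is new or still open speak of the compounds shown alone.

The series shares one core, shown in compound 1 `O=c1ccc2cc(OCc3cn(-c4ccccc4)nn3)ccc2o1`, which in a functional assay on COLO 205 cells (Homo sapiens) for cytotoxicity, read by MTT assay, with a stated time of 48 h (on this read-out lower numbers stand for stronger inhibition and higher numbers for weaker inhibition), gives 48800 nM. Compound 2 `COc1ccc(-n2cc(COc3ccc4oc(=O)ccc4c3)nn2)cc1` carries a methoxy in place of hydrogen on an aromatic carbon; in this assay compound 2 gives 32800 nM. Compound 3 `O=c1ccc2cc(OCc3cn(-c4ccccc4[N+](=O)[O-])nn3)ccc2o1` bears a 2-nitrophenyl on an aromatic nitrogen; in this assay compound 3 gives "not determined" (no result reported), so no number places it against the other two. Compound 4 `O=c1ccc2cc(OCc3cn(-c4ccc([N+](=O)[O-])cc4)nn3)ccc2o1` differs from compound 3 by 4-nitrophenyl in place of 2-nitrophenyl on an aromatic nitrogen. Among the compounds with values here, no measured step bears on this change directly, and compound 3 itself offers nothing to anchor one. Within the data shown here, the single paired comparison available, a 1.5-fold lower number from compound 1 to compound 2 (0.17 log units; within the scatter), concerns a different group on the phenyl and stays within the scatter; it shows only that both measured compounds sit in a region of weak inhibition. Nothing recorded speaks for a nitrophenyl on the ring nitrogen moving the number far from there, so compound 4 is expected to land in the same weak region, at an estimated 40000 nM with a range from 12000 nM to 130000 nM.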

Compound 4, half-maximal inhibitory concentration: 48700 nM
The estimate for compound 4 lay 1.2-fold (0.09 log units) below the measured number; the range from low to high includes it.
By their numbers in this assay, from the lowest: compounds 2, 4 and 1 (each within the scatter of the next).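

In this assay the new result adds a 1.0-fold lower number from compound 1 to compound 4 (0.00 log units; within the scatter) and a 1.5-fold higher number from compound 2 to compound 4 (0.17 log units; within the scatter) for nitro in place of hydrogen and of methoxy on an aromatic carbon. The earlier compounds had shown only one group on this phenyl, whereas nitro now gives a second, and compounds 1, 2 and 4 all stay within the scatter of one another in a region of weak inhibition, with neither methoxy nor the 4-nitrophenyl setting itself apart from the unsubstituted phenyl. Nothing measured here on these compounds accounts for this flat result.

On these data alone, the step from compound 3 to compound 4 cannot be read: compound 3 has no number, and whether the 2-nitrophenyl and the 4-nitrophenyl differ on the aromatic nitrogen stays open. The compounds shown also leave open whether an amine, a carboxylic acid or a longer chain on this phenyl would move the number out of the weak region.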